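Propylsulfanyl in Place of (2,6-Dichlorobenzyl)sulfanyl on a Shared Core

The source may hold more compounds than are shown below. What is called first, only, known or untested is meant among the compounds shown, and "the series" means these compounds.

Measured so far:
compound 1 `Cc1cc(Nc2cc(-c3ccccc3)[nH]n2)n2nc(SCc3c(Cl)cccc3Cl)nc2n1`: 39600 nM
compound 2 `Cc1cc(Nc2ccn(Cc3ccccc3)n2)n2nc(SCc3ccc(Br)cc3)nc2n1`: 44400 nM
compound 3 `Cc1cc(Nc2ccn(Cc3ccc(F)cc3)n2)n2nc(SCc3ccc(Br)cc3)nc2n1`: 40500 nM

In an ADME assay on GES1 cells (Homo sapiens) for inhibition, read by MTT assay, with a stated time of 72 h (on this read-out higher numbers stand for weaker inhibition and lower numbers for stronger inhibition), compound 1 gives 39600 nM. This is the lowest of the three numbers, but its gaps to compound 3 and compound 2 are both within the scatter, so the three compounds stand together. Going by the values given here, the only step between measured compounds, a 1.1-fold lower number from compound 2 to compound 3 (0.04 log units; within the scatter), lay within the scatter.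

Compound 4 `CCCSc1nc2nc(C)cc(Nc3cc(-c4ccccc4)[nH]n3)n2n1` differs from compound 1 by ethyl in place of 2,6-dichlorophenyl on a saturated chain carbon bound to a sulfur. Among the compounds with values here, no measured step touches this position; the one step available concerns a different part of the molecule, so nothing in the data points to a direction. Compound 4 is therefore expected to give 42000 nM, with a range from 15000 nM to 110000 nM. The expected step is a 1.1-fold higher number from compound 1 to compound 4 (0.03 log units; within the scatter), no more than the scatter.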

Compound 4, half-maximal inhibitory concentration: > 50000 nM
Compound 4: no number, only a limit; the forecaster's own chance of this, stated with the estimate: 20%; at least 1.1-fold (0.07 log units) between middle value and limit.
By their numbers in this assay, from the lowest: compounds 1, 3 and 2 (each within the scatter of the next). At a limit, above all of these: compound 4.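

Propylsulfanyl in place of (2,6-dichlorobenzyl)sulfanyl gives an at least 1.2-fold higher number from compound 1 to compound 4 (0.10 log units; that floor lies within the scatter) in this assay, so losing the aromatic ring at this position brings no stronger inhibition. The reading for compound 4 is a limit and not a number, so the true size of this step cannot be read: the limit of > 50000 nM in this assay, at which 1 of the 4 values shown sits.

Going by these compounds, whether an amine, a carboxylic acid or a longer chain on the sulfur would give a number in this assay stays open. So does whether the same change would behave alike on the rest of compound 2 or compound 3.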